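The source may hold more compounds than are shown below. What is called first, only, known or untested is meant among the compounds shown, and "the series" means these compounds.

In a functional assay on HeLa cells (Homo sapiens) for antiproliferative activity, with a stated time of 24 h (a higher number here means a weaker inhibitor, a lower number a stronger inhibitor), compound 1 (`NC(=O)c1c(NC(=O)c2ccccc2C(F)(F)F)sc2c1CCN(C(=S)Nc1ccccc1Cl)C2`) gives a measured number (46900 nM). For compound 2 (`COc1ccccc1NC(=S)N1CCc2c(sc(NC(=O)c3ccccc3I)c2C(N)=O)C1`) there is only a limit of the assay and no number (> 50000 nM). Compound 2 therefore has no exact position on the scale, only this mark (the limit of > 50000 nM in this assay, at which 1 of the 2 values shown sits).

Compound 3 (`COc1ccccc1NC(=S)N1CCc2c(sc(NC(=O)c3ccccc3C(F)(F)F)c2C(N)=O)C1`) has not yet been measured. It differs from compound 2 in one place, with trifluoromethyl in place of iodo on an aromatic carbon. That carbon belongs to a six-membered aromatic ring of carbon only and is ortho to a large group.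

Going by the values given here, no measured step tests this exchange, so any expectation rests on little. The 2-(trifluoromethyl)phenyl group that enters is also present in compound 1 (46900 nM), which suggests that compound 3 will remain a very weak inhibitor. A small change toward stronger inhibition is expected in this assay for this exchange (an at least 1.1-fold lower number from compound 2 to compound 3 (0.07 log units; that floor lies within the scatter)). The estimate for compound 3 is 42000 nM within an expected range of 18000 nM to 90000 nM and the assay may again report only a limit.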

Compound 3, half-maximal inhibitory concentration: > 50000 nM
Compound 3 ended at the assay's limit (the forecaster's own chance of this, stated with the estimate: 45%); middle value at least 1.1-fold (0.07 log units) away from the limit.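

Compound 2 and compound 3 both end at a limit in this assay, so the step between them cannot be read, and the result shows only that neither iodo nor trifluoromethyl at this position brings the methoxy-bearing compounds to a measured number: the limit of > 50000 nM in this assay, at which 2 of the 3 values shown sit.

Going by these compounds alone, the one comparison that can be read concerns a different place, where methoxy stands in place of chloro on an aromatic carbon and gives an at least 1.0-fold higher number from compound 1 to compound 3 (0.02 log units; that floor lies within the scatter). Since that floor lies within the scatter, the exchange may have little effect, although a larger one is not excluded, and with the 2-(trifluoromethyl)phenyl group present compound 1 alone gives a number.

As far as these compounds go, how far beyond the limit compound 2 and compound 3 lie remains unknown, so iodo and trifluoromethyl cannot be ranked at this position. From the compounds shown here alone, it also remains open whether an amine, a carboxylic acid or a longer chain on this aromatic carbon would bring the shared core to a clearly stronger value in this assay.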